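Changing the Amide Substituent on an Inactive Compound

A few compounds are considered here, and "the series" means these few. Any claim that something is new, unique, unknown or untested is made for them only; others in the source may bear on it.

Compound 1 `CN1CCc2nc(C#Cc3cccc(F)c3)sc2C1`: in an assay on HEK293 cells for negative allosteric modulation of metabotropic glutamate receptor 5 (Homo sapiens), read by FLIPR, with a stated time of 1 h (a lower number here means a stronger inhibitor, a higher number a weaker inhibitor), compound 1 gives > 10000 nM, a limit of the assay rather than a number.
Compound 2 `Fc1cccc(C#Cc2nc3c(s2)CN(C2CCOC2)CC3)c1`: in this assay compound 2 gives 400 nM.
Compound 3 `CC1CC1C(=O)N1CCc2nc(C#Cc3ccccc3)sc2C1`: in this assay compound 3 gives > 10000 nM, again a limit of the assay.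

Compound 3 therefore stands at the weak end of what has been measured, with no number of its own; two of the three values shown sit at that limit (the limit of > 10000 nM in this assay, at which 2 of the 3 values shown sit). Compound 4 `O=C(C1CCCCO1)N1CCc2nc(C#Cc3ccccc3)sc2C1` differs from compound 3 in a single place: oxan-2-yl in place of 2-methylcyclopropyl on a carbonyl carbon.

For the measured compounds named here, only one measured step exists, an at least 25-fold lower number from compound 1 to compound 2 (1.39 log units; beyond the scatter), and it changes the group on an amine nitrogen in a ring, whereas the present change sits on a carbonyl carbon of an amide-type nitrogen in a ring. That step shows a ring substituent can move the value by a large amount, but it gives no direct guide to exchanging one carbonyl substituent for another. With no closer comparison, the expectation is that compound 4 stays near where compound 3 stands, and the step of a number no higher from compound 3 to compound 4 (the limit leaves the size open) is expected to lie within the scatter. Compound 4 is estimated at 10000 nM in this assay, with a range from 2000 nM to 40000 nM.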

Compound 4, half-maximal inhibitory concentration: > 10000 nM
Compound 4 ended at the assay's limit; the forecaster's own chance of this, stated with the estimate: 65%; the middle value sits exactly at the limit.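

For the compounds shown here, compound 3 and compound 4 both stand at a limit in this assay rather than at a number, so no step between them can be read: the limit of > 10000 nM in this assay, at which 3 of the 4 values shown sit. The compounds shown leave open whether exchanging 2-methylcyclopropyl for oxan-2-yl on the carbonyl carbon changes the value at all, and what numbers compound 3 and compound 4 would have.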